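The source may report more compounds than this note shows. Statements on the series, on what has been measured and on what is new or still open speak of the compounds shown alone.

Working notes on the series. Compound 1 `CC(C)Nc1nc(NCc2ccco2)c2ccccc2n1` has been run in a physicochemical assay for solubility, at pH 7.4; a lower number here means a less soluble compound, a higher number a more soluble compound; compound 1 gives >= 30000 nM, which is a limit of the assay rather than a number. Compound 2 `CCOC(=O)CNc1nc(NC(C)C)nc2ccccc12` gives <= 20000 nM, also a limit. Compound 3 `CC(C)Nc1nc(N(C)C)c2ccccc2n1` gives <= 10000 nM, again a limit. Going by the values given here, the only measured steps are an at least 1.5-fold lower number from compound 1 to compound 2 (0.17 log units; that floor lies within the scatter) and an at least 3.0-fold lower number from compound 1 to compound 3 (0.47 log units; beyond the scatter); both alter the substituent on an aromatic carbon bearing nitrogen, and neither touches the six-membered aromatic ring of carbon only. Compound 4 `CC(C)Nc1nc(NCc2ccco2)c2cccc(Cl)c2n1` differs from compound 1 by chloro in place of hydrogen on an aromatic carbon. Among the compounds with values here, no measured step bears on this change, so no step beyond the scatter is expected in this assay in either direction. Compound 4 is accordingly estimated at 20000 nM, with a range from 6000 nM to 60000 nM. The step this estimate implies is expected to be an at least 1.5-fold lower number from compound 1 to compound 4 (0.17 log units; that floor lies within the scatter).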

Compound 4, solubility: <= 5000 nM
Compound 4 ended at the assay's limit; the forecaster's own chance of this, stated with the estimate: 50%; at least 4.0-fold (0.60 log units) between middle value and limit.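

Chloro in place of hydrogen on an aromatic carbon of the six-membered aromatic ring of carbon only, a part of the core that no earlier step touched, gives in this assay an at least 6.0-fold lower number from compound 1 to compound 4 (0.77 log units; beyond the scatter). That size is only a floor, since compound 4 stands at a limit of the assay: the limit of <= 5000 nM in this assay, at which 1 of the 4 values shown sits. Compound 1 also stands at a limit: the limit of >= 30000 nM in this assay, at which 1 of the 4 values shown sits.

Open, from the compounds shown here alone, is whether fluoro, methoxy or an amine at this position would give a similar step. Also open, going by these compounds, is whether chloro on another carbon of that ring would.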